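Compound 3 to compound 4: loss of the cyano group

The source may report more compounds than this note shows. Statements on the series, on what has been measured and on what is new or still open speak of the compounds shown alone.

Measured compounds, all values being limits of an ADME assay on cells (Peritoneal macrophage cell, Mus musculus) for cytotoxicity, read by fluorescence and resazurin assay, with a stated time of 3 days; a higher number here means that more compound is tolerated, a lower number that less compound is tolerated:
Compound 1 `O=C(Nc1[nH]nc(-c2ccccn2)c1C1CC1)c1ccccc1F` gives the limit > 64000 nM
Compound 2 `COc1ccc(C(=O)Nc2[nH]nc(-c3ccccn3)c2C2CC2)cc1` gives the limit > 64000 nM
Compound 3 `N#Cc1ccc(C2CCN(C(=O)Nc3cc(-c4ccccn4)n[nH]3)CC2)cc1` gives the limit > 64000 nM

Compound 3 has no numerical value in this assay and shares its position with the other two measured compounds. Among the compounds with values here, the series so far is summed up by the limit of > 64000 nM in this assay, at which 3 of the 3 values shown sit, and contains no number to rank against.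

Compound 4 `O=C(Nc1cc(-c2ccccn2)n[nH]1)N1CCC(c2ccccc2)CC1` differs from compound 3 by hydrogen in place of cyano on an aromatic carbon. This is hydrogen in place of cyano on an aromatic carbon, para to a large group, or 4-cyanophenyl to phenyl.

Within the data shown here, only one measured step exists: a step that the two limits leave unreadable from compound 1 to compound 2. It involves a different change at a different place, and its size cannot be read, so it offers no size to carry over. Among the measured compounds shown here, no measured step bears directly on the loss of cyano.

With no contrary evidence, no shift beyond the scatter and no direction is expected in this assay, and compound 4 is expected to be reported as a limit as well. The expected outcome is a number no higher from compound 3 to compound 4 (the limit leaves the size open) in this assay. For compound 4 the estimated half-maximal cytotoxic concentration is 64000 nM with an expected range from 32000 nM to 128000 nM.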

Compound 4, half-maximal cytotoxic concentration: > 64000 nM
Compound 4: no number, only a limit; the forecaster's own chance of this, stated with the estimate: 85%; the middle value lies on the limit itself.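

In this assay compound 4 gives > 64000 nM, which is a limit, and compound 3 also stands only as a limit, so no step can be read between compound 3 and compound 4. The compounds shown leave open whether hydrogen in place of cyano shifts tolerance at all, and what any compound's actual half-maximal cytotoxic concentration is, since all share one position: the limit of > 64000 nM in this assay, at which 4 of the 4 values shown sit.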